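The source may hold more compounds than are shown below. What is called first, only, known or untested is meant among the compounds shown, and "the series" means these compounds.

Compound 1 `CC(C)c1n[nH]c2c(NCc3ccc(-c4ccccn4)cc3)nc(S(C)(=O)=O)nc12` gives 793 nM in a functional assay on G-361 cells (Homo sapiens) for cytotoxicity, read by fluorescence, with a stated time of 72 h (on this read-out higher numbers stand for weaker inhibition and lower numbers for stronger inhibition), the highest of the two numbers in hand. Among the measured compounds shown here, compound 2 `CC(C)c1n[nH]c2c(NCc3ccc(-c4ccccn4)cc3)nc(NCCN)nc12` gives 230 nM in this assay, and the only measured step is a 3.4-fold lower number from compound 1 to compound 2 (0.54 log units; beyond the scatter). Compound 3 `CC(C)c1n[nH]c2c(NCc3ccc(-c4ccccn4)cc3)nc(NCC(N)CO)nc12` differs from compound 1 by a group of 6 heavy atoms (3 carbon, 2 nitrogen, 1 oxygen; no ring) in place of a group of 4 heavy atoms (1 carbon, 2 oxygen, 1 sulfur; no ring), on an aromatic carbon. The step from compound 1 to compound 2 bears on this, both changes putting a chain with nitrogen in place of methylsulfonyl on an aromatic carbon. A lowering of similar size is therefore expected, a 3.1-fold lower number from compound 1 to compound 3 (0.48 log units; beyond the scatter). Compound 3 is estimated at 260 nM, within 120 nM to 600 nM.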

Compound 3, half-maximal inhibitory concentration: 1020 nM
Beside the measured number, compound 3's estimate is 3.9-fold (0.59 log units) below it; measured number above the stated range.
By their numbers in this assay, from the lowest: compound 2; then compounds 1 and 3 (each within the scatter of the next).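

Putting a nitrogen-bearing chain in place of methylsulfonyl on this aromatic carbon does not by itself change the number: this assay gives a 1.3-fold higher number from compound 1 to compound 3 (0.11 log units; within the scatter). The chain's make-up matters, as hydroxymethyl in place of hydrogen on its saturated carbon gives a 4.4-fold higher number from compound 2 to compound 3 (0.65 log units; beyond the scatter). No evidence is at hand on why these two chains differ.

The compounds shown leave open whether a methyl group at that chain carbon would behave as hydroxymethyl does. They also leave open how a longer aminoalkyl chain, or a hydroxyl in place of the terminal amine, would compare with compound 2.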